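This account rests on a few compounds, and the source may have more. Where it says the series, first, only, none or still open, it means among the compounds named here.

Compound 1 `COc1ccc(-c2cc3ccccc3nc2/C=C/C(=O)c2ccc(F)cc2)cc1`: > 10000 nM in a functional assay on H184B5F5/M10 cells (Homo sapiens) for antiproliferative activity, read by XTT assay, with a stated time of 72 h (a lower number here means a stronger inhibitor, a higher number a weaker inhibitor), a limit of the assay rather than a number. Compound 2 `COc1ccc(-c2cc3ccccc3nc2/C=C/C(=O)c2ccc(O)cc2)cc1`: 5690 nM.

Compound 1 thus stands only at a limit, (the limit of > 10000 nM in this assay, at which 1 of the 2 values shown sits), with no number of its own. Compound 3 `COc1ccc(-c2cc3ccccc3nc2/C=C/C(=O)c2sccc2N)cc1` differs from compound 1 by 3-aminothiophen-2-yl in place of 4-fluorophenyl on a carbonyl carbon. Among the compounds with values here, the single measured step, an at least 1.7-fold lower number from compound 1 to compound 2 (0.24 log units; that floor lies within the scatter), changes the same ring in another way and carries no clear signal, so nothing measured bears directly on this change. No shift beyond the scatter is therefore expected. Compound 3 is estimated at 8000 nM, with a range from 2000 nM to 30000 nM, which would mean a step of an at least 1.2-fold lower number from compound 1 to compound 3 (0.09 log units; that floor lies within the scatter).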

Compound 3, half-maximal inhibitory concentration: > 10000 nM
Compound 3 ended at the assay's limit (the forecaster's own chance of this, stated with the estimate: 45%); middle value at least 1.2-fold (0.09 log units) from the limit.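

In this assay, putting 3-aminothiophen-2-yl in place of 4-fluorophenyl on the carbonyl carbon gives no readable step, because compound 1 and compound 3 both stand at a limit: the limit of > 10000 nM in this assay, at which 2 of the 3 values shown sit. Set against 4-hydroxyphenyl, the same group shows an at least 1.7-fold higher number from compound 2 to compound 3 (0.24 log units; that floor lies within the scatter), so no clear difference appears there either. Compound 2 remains the only one of the three with a number of its own, 5690 nM. On these data alone, it stays open whether any group on this carbonyl carbon moves the number clearly, and what a carboxylic acid or an open-chain amine would give there.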